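The source may report more compounds than this note shows. Statements on the series, on what has been measured and on what is new or still open speak of the compounds shown alone.

Compound 2 `Cc1cc(Nc2ccn(Cc3nc(C)c4ccccc4n3)n2)n2nc(SCc3ccc(Br)cc3)nc2n1` gives the lowest of the three numbers in a functional assay on MCF7 cells (Homo sapiens) for inhibition, read by MTT assay, with a stated time of 72 h (a higher number here means a weaker inhibitor, a lower number a stronger inhibitor), at 1430 nM. Compound 3 `Cc1cc(Nc2cc(-c3ccccc3)[nH]n2)n2nc(SCc3ccc(C(F)(F)F)cc3)nc2n1` gives 4820 nM in this assay, and compound 1 `Cc1cc(Nc2cc(-c3ccccc3)[nH]n2)n2nc(SCc3ccc(Cl)cc3)nc2n1` gives 8260 nM in this assay. For the measured compounds named here, the only measured step, a 1.7-fold lower number from compound 1 to compound 3 (0.23 log units; within the scatter), sits elsewhere in the molecule and says nothing about the group on the saturated chain carbon bound to an aromatic nitrogen. Compound 4 `Cc1cc(Nc2ccn(Cc3ccc(F)cc3)n2)n2nc(SCc3ccc(Br)cc3)nc2n1` differs from compound 2 by 4-fluorophenyl in place of 4-methylquinazolin-2-yl on a saturated chain carbon bound to an aromatic nitrogen. Going by the values given here, no measured step bears on this change, so its size and direction are open; the estimate leans toward a somewhat higher number, with a wide range. Compound 4 is expected to give 3000 nM in this assay, between 1000 nM and 9000 nM. That expectation amounts to a step of a 2.1-fold higher number from compound 2 to compound 4 (0.32 log units; beyond the scatter).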

Compound 4, half-maximal inhibitory concentration: 4280 nM
The estimate for compound 4 lay 1.4-fold (0.15 log units) below the measured number; measured number inside the range.
By their numbers in this assay, from the lowest: compound 2; then compounds 4, 3 and 1 (each within the scatter of the next).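

On a saturated chain carbon bound to an aromatic nitrogen, replacing 4-methylquinazolin-2-yl with 4-fluorophenyl gives a 3.0-fold higher number from compound 2 to compound 4 (0.48 log units; beyond the scatter) in this assay. For the compounds shown here, this is the first reading at this position, and it shows that the group held there can shift the number beyond the scatter, with the 4-methylquinazolin-2-yl compound giving the lower number. Nothing in hand explains this step.

On these data alone, it remains open how an amine, a carboxylic acid or a longer chain would read on this carbon. As far as these compounds go, whether the step keeps its size with trifluoromethyl or chloro in place of the bromo group is also open.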